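Phenyl for Methyl on a Shared Core: Expected Cytotoxicity

A few compounds are considered here, and "the series" means these few. Any claim that something is new, unique, unknown or untested is made for them only; others in the source may bear on it.

Compound 1 `Cn1nnc2c(C(N)=O)cccc2c1=O` was tested in a functional assay on TLX-5 cells (Mus musculus) for cytotoxicity; a lower number here means a stronger inhibitor, a higher number a weaker inhibitor. In this assay compound 1 gives > 500000 nM, and this is a limit of the assay rather than a number. Among the compounds with values here, compound 1 therefore stands only at a limit, with no measured value of its own; the single piece of evidence on it is the limit of > 500000 nM in this assay, at which 1 of the 2 values shown sits. Compound 2 `NC(=O)c1cccc2c(O)nnnc12` carries the same amide on the shared core, and in this assay compound 2 gives 400000 nM. Within the data shown here, no step between compound 1 and compound 2 is computed, so their two values show only that both lie at a very high concentration. Compound 3 `NC(=O)c1cccc2c(=O)n(-c3ccccc3)nnc12` has not yet been measured in this assay. It differs from compound 1 in one place: phenyl in place of methyl on an aromatic nitrogen. No measured step of this kind exists among these compounds, so nothing here tells the size of the change. The step expected here is an at least 1.2-fold lower number from compound 1 to compound 3 (0.09 log units; that floor lies within the scatter), none beyond the scatter. Compound 3 is estimated at 400000 nM, within 100000 nM to 1500000 nM, with a fair chance that only a limit is reported.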

Compound 3, half-maximal inhibitory concentration: > 500000 nM
Compound 3 was reported as a limit; the forecaster's own chance of this, stated with the estimate: 55%; at least 1.2-fold (0.09 log units) between middle value and limit.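

In this assay compound 3 gives > 500000 nM, which is a limit of the assay and not a number. Compound 1 also stands at a limit, so no step can be read between compound 1 and compound 3. Whether phenyl in place of methyl on an aromatic nitrogen changes the number at all stays open, as most of the compounds shown rest on one limit: the limit of > 500000 nM in this assay, at which 2 of the 3 values shown sit.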